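The source may hold more compounds than are shown below. What is called first, only, known or untested is meant among the compounds shown, and "the series" means these compounds.

In a functional assay, read by spectrophotometry, with a stated time of 15 min, tested at 80 ug/mL (a higher number here means a stronger effect of the compound at the concentration tested, a lower number a weaker effect), three compounds have been measured. Compound 1 `COC(=O)c1cc(-c2csc(N/N=C/c3cccs3)n2)ccc1OCc1ccccc1` gives 87.6%, compound 2 `Clc1ccc(-c2csc(N/N=C/c3cccs3)n2)cc1` gives 86%, and compound 3 `Cc1ccc(-c2csc(N/N=C/c3ccc(Cl)cc3Cl)n2)cc1` gives 84.2%. Compound 3 stands at the lower end of these three numbers, but the values of compound 2 and compound 1 both lie within the scatter of it, so no order among the three can be read. Compound 4 `Clc1ccc(/C=N/Nc2nc(-c3ccccc3)cs2)c(Cl)c1` has not yet been tested in this assay. It differs from compound 3 by one change, (hydrogen in place of methyl on an aromatic carbon). For the measured compounds named here, no step between measured compounds shows the effect of this change, so the expectation rests only on the closeness of the three numbers. The step of a number 1.2 percentage points lower from compound 3 to compound 4 (within the scatter) is expected to be none beyond the scatter. The estimate for compound 4 in this assay is 83%, with a range from 72% to 91%.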

Compound 4, a percentage reported as inhibition, at one concentration (the size of the read-out at that concentration, not a potency): 83.1%
For compound 4 the middle estimate is 0.1 percentage points below the measured one; measured number inside the range.
By their numbers in this assay, from the lowest: compounds 4, 3, 2 and 1 (each within the scatter of the next).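

For the compounds shown here, with a number 1.1 percentage points lower from compound 3 to compound 4 (within the scatter) in this assay the change from 4-methylphenyl to phenyl is read directly for the first time. At this place, para to a large group, hydrogen in place of methyl leaves the read-out within the scatter at the one concentration tested. Nothing available explains this result.

Going by these compounds, whether another group at this place, such as an amine, a carboxylic acid or a longer chain, would move the read-out remains open. This single step also says nothing about potency, and it does not show whether the same change would behave alike on another compound.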